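The source may report more compounds than this note shows. Statements on the series, on what has been measured and on what is new or still open speak of the compounds shown alone.

Compound 1 `CCC(C)(C)/N=c1\c(O)c(O)\c1=N/Cc1ccc(C#N)c(Cl)c1` and compound 2 `CCC(C)(C)/N=c1\c(O)c(O)\c1=N/Cc1c(Cl)cccc1Cl` are built on cores that differ from each other; how the two cores differ is not broken down here. In a functional assay for inhibition, with Rattus norvegicus as the target (a higher number here means a weaker inhibitor, a lower number a stronger inhibitor), compound 1 gives 260 nM, and compound 2 gives 280 nM, two numbers that lie within the scatter of each other. Compound 3 `CC(C)(C)/N=c1\c(O)c(O)\c1=N/Cc1ccc(C#N)c(Cl)c1` is compound 1 with a single change, (hydrogen in place of methyl on a saturated chain carbon, two bonds along the chain from a double-bonded nitrogen), and in this assay compound 3 gives 1100 nM. That change made a 4.2-fold higher number from compound 1 to compound 3 (0.63 log units; beyond the scatter). Compound 4 `CC(C)(C)/N=c1\c(O)c(O)\c1=N/Cc1c(Cl)cccc1Cl`, which has not yet been measured, is compound 2 with the same change, (hydrogen in place of methyl on a saturated chain carbon, two bonds along the chain from a double-bonded nitrogen), made at the same place, so this change appears twice among the four compounds. For compound 4 a step of similar size is expected, a 4.1-fold higher number from compound 2 to compound 4 (0.61 log units; beyond the scatter). Among the measured compounds shown here, this expectation rests on the one measured example of the change, a 4.2-fold higher number from compound 1 to compound 3 (0.63 log units; beyond the scatter), and on the fact that compound 1 and compound 2 give numbers within the scatter of each other. On that basis compound 4 is estimated to give 1150 nM in this assay, most likely between 500 nM and 2700 nM.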

Compound 4, half-maximal inhibitory concentration: 1100 nM
Beside the measured number, compound 4's estimate is 1.0-fold (0.02 log units) above it; low and high end bracket the measured number.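

In this assay, replacing 1,1-dimethylpropyl with tert-butyl weakens inhibition on the second core too, with a 3.9-fold higher number from compound 2 to compound 4 (0.59 log units; beyond the scatter). Set side by side, the two steps agree: the same change on two cores in this assay, a 4.2-fold higher number (0.63 log units; beyond the scatter) from compound 1 to compound 3 and a 3.9-fold higher number (0.59 log units; beyond the scatter) from compound 2 to compound 4, 1.1-fold (0.03 log units) apart, within the scatter of two such steps. In these two pairs, then, the change carries from one core to the other at about the same size, so the step measured on one core would have served as a fair guide to the other; however, two cores in a single assay do not show that it would hold on every core in the series, and the numbers do not explain why removing this methyl weakens inhibition.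

The compounds shown carry only the 1,1-dimethylpropyl and tert-butyl groups at this place, so how a longer chain, a cyclohexyl ring or an amine there would compare remains open. From the compounds shown here alone, whether the same step would appear on a third core also remains open.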